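Phenyl to tert-butyl on the amide nitrogen

The source may report more compounds than this note shows. Statements on the series, on what has been measured and on what is new or still open speak of the compounds shown alone.

Among the measured compounds shown here, compound 2 `O=C(Nc1ccccc1)C(=O)Nc1ccc2c(c1)COC2=O` gives 36100 nM in a functional assay on cells (T-cell, Mus musculus) for inhibition (on this read-out lower numbers stand for stronger inhibition and higher numbers for weaker inhibition), the only numerical value in the set so far. Compound 1 `CN(C(=O)Nc1ccc2c(c1)COC2=O)c1ccccc1` returns only a limit of this assay, > 100000 nM, not a number (the limit of > 100000 nM in this assay, at which 1 of the 2 values shown sits). Compound 3 `CC(C)(C)NC(=O)C(=O)Nc1ccc2c(c1)COC2=O` differs from compound 2 by tert-butyl in place of phenyl on an amide-type nitrogen. For the measured compounds named here, no measured step of this kind exists here, so the expected step is a weakening of inhibition in this assay, probably somewhat beyond the usual scatter: a 1.9-fold higher number from compound 2 to compound 3 (0.29 log units; within the scatter). Compound 3 is therefore estimated at about 70000 nM, within 20000 nM to 250000 nM, with a fair chance that only a limit is reported.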

Compound 3, half-maximal inhibitory concentration: 3400 nM
The estimate for compound 3 lay 21-fold (1.31 log units) above the measured number; the whole stated range lies above it.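

In this assay tert-butyl in place of phenyl gives an 11-fold lower number from compound 2 to compound 3 (1.03 log units; beyond the scatter) and so an aromatic ring on this amide-type nitrogen is not needed for inhibition. The position responds strongly to the group it carries, and a branched group without a ring is accepted there. Among the compounds shown here, nothing measured so far gives a reason for this step.

From the compounds shown here alone, it remains open whether the gain comes from the branching or from the loss of the ring, which isopropyl or cyclohexyl on the same nitrogen would help separate. Going by these compounds, whether an amine or a carboxylic acid is accepted at this position also remains open.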